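The source may hold more compounds than are shown below. What is called first, only, known or untested is meant among the compounds shown, and "the series" means these compounds.

Measured so far in a functional assay on PC-3 cells (Homo sapiens) for antiproliferative activity, read by MTT assay, with a stated time of 48 h; on this read-out higher numbers stand for weaker inhibition and lower numbers for stronger inhibition:
compound 1 `COc1ccc(CN(C(=O)CSc2nc3ccccc3s2)c2cc(OC)c(OC)c(OC)c2)cc1C`: compound 1 gives 34300 nM
compound 2 `COc1cc(N(Cc2ccc(C)cc2)C(=O)CSc2nc3ccccc3s2)cc(OC)c1OC`: compound 2 gives > 80000 nM, a limit of the assay and not a number
compound 3 `COc1cc(CN(C(=O)CSc2nc3ccccc3s2)c2cc(OC)c(OC)c(OC)c2)cc(OC)c1OC`: compound 3 gives > 80000 nM, likewise a limit and not a number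

Compound 3 stands at the limit of this assay, so only an upper bound on its potency is known; it shares that position with one other value (the limit of > 80000 nM in this assay, at which 2 of the 3 values shown sit). Compound 4 `COc1ccc(CN(C(=O)CSc2nc3ccccc3s2)c2cc(OC)c(OC)c(OC)c2)cc1C(F)(F)F` differs from it in one place: 4-methoxy-3-(trifluoromethyl)phenyl in place of 3,4,5-trimethoxyphenyl on a saturated chain carbon bound to an amide-type nitrogen. The step that bears on this is an at least 2.3-fold higher number from compound 1 to compound 3 (0.36 log units; beyond the scatter), which runs the other way, from a 4-methoxy-3-methylphenyl to the 3,4,5-trimethoxyphenyl; the step that the two limits leave unreadable from compound 2 to compound 3 adds nothing readable. Compound 4 is therefore expected to give a lower number than the limit seen for compound 3, an expected step of an at least 2.0-fold lower number from compound 3 to compound 4 (0.30 log units; that floor lies within the scatter), its size uncertain since compound 3 is known only as a limit. For compound 4 the estimate in this assay is 40000 nM, with a range from 15000 nM to 120000 nM.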

Compound 4, half-maximal inhibitory concentration: > 80000 nM
Compound 4 ended at the assay's limit (the forecaster's own chance of this, stated with the estimate: 35%); at least 2.0-fold (0.30 log units) between middle value and limit.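

In this assay compound 4 gives > 80000 nM, a limit and not a number: the limit of > 80000 nM in this assay, at which 3 of the 4 values shown sit.

Trifluoromethyl in place of methyl on an aromatic carbon gives an at least 2.3-fold higher number from compound 1 to compound 4 (0.36 log units; beyond the scatter), so the 4-methoxy group alone does not keep a readable value at this position; among the four groups shown, only the 4-methoxy-3-methylphenyl of compound 1 does. The steps from compound 2 and compound 3 to compound 4 cannot be read, since both ends are limits.

Still open, on these data alone, is whether a small group other than methyl on that aromatic carbon, such as an amine or a hydroxyl, would match or improve on compound 1 with its 34300 nM.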